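Fluoro added to the aromatic ring of compound 1

The source may report more compounds than this note shows. Statements on the series, on what has been measured and on what is new or still open speak of the compounds shown alone.

Within the data shown here, in a functional assay on U-373MG ATCC cells (Homo sapiens) for inhibition, read by colorimetric assay and MTT assay, with a stated time of 72 h (on this read-out higher numbers stand for weaker inhibition and lower numbers for stronger inhibition), compound 1 `C=CCCCCOc1ccccc1-c1cnc(OCCC=C)n1C` gives 33000 nM, the lowest of the three numbers so far. Compound 2 `C=CCCCCOc1ccc(OC)cc1-c1cnc(OCCC=C)n1C` gives 67000 nM, and compound 3 `C=CCCCCOc1ccc(F)cc1-c1cnc(OCCC=C)n1C` gives 73000 nM. Compound 4 `C=CCCCCOc1cc(F)ccc1-c1cnc(OCCC=C)n1C` carries fluoro in place of hydrogen on an aromatic carbon, meta to a (hex-5-en-1-yl)oxy group and para to a large group: fluoro in place of hydrogen on an aromatic carbon.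

Among the measured compounds shown here, two measured steps bear most directly on this change. The fluoro step is a 2.2-fold higher number from compound 1 to compound 3 (0.34 log units; beyond the scatter), and the methoxy step is a 2.0-fold higher number from compound 1 to compound 2 (0.31 log units; beyond the scatter). Both are modest and both raise the number, while a 1.1-fold higher number from compound 2 to compound 3 (0.04 log units; within the scatter) stays within the scatter. In compound 2 and compound 3, however, the added group stands on a different aromatic carbon from the fluoro of compound 4, so these steps are only a loose guide. A modest rise is therefore expected in this assay, and the estimated step is a 1.7-fold higher number from compound 1 to compound 4 (0.22 log units; within the scatter). For compound 4 the estimate is 55000 nM, with an expected range of 24000 nM to 120000 nM.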

Compound 4, half-maximal inhibitory concentration: > 100000 nM
Compound 4: no number, only a limit; the forecaster's own chance of this, stated with the estimate: 10%; middle value at least 1.8-fold (0.25 log units) from the limit.
By their numbers in this assay, from the lowest: compound 1; then compounds 2 and 3 (each within the scatter of the next). At a limit, above all of these: compound 4.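

In this assay, compound 4 reads only as a limit: the limit of > 100000 nM in this assay, at which 1 of the 4 values shown sits. Fluoro in place of hydrogen on this aromatic carbon, meta to a (hex-5-en-1-yl)oxy group and para to a large group, gives an at least 3.0-fold higher number from compound 1 to compound 4 (0.48 log units; beyond the scatter), so this carbon joins the fluoro site of compound 3 as a second place where fluoro raises the number beyond the scatter. This step gives a bound rather than a size, and compound 4 now stands above compounds 1, 2 and 3, with compound 1 still the lowest.

As far as these compounds go, how far the true number of compound 4 lies past the limit stays open, so its step cannot be sized against the fluoro step to compound 3. Also open, from the compounds shown here alone, is whether an amine or a carboxylic acid on this aromatic carbon would keep the number near that of compound 1 or raise it as fluoro does.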